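This account rests on a few compounds, and the source may have more. Where it says the series, first, only, none or still open, it means among the compounds named here.

Compound 2 `CC1CCN(c2c(S(=O)(=O)c3ccc(Cl)c(Cl)c3)cnc3ccc(F)cc23)CC1` is one of two compounds that have been measured in an assay on isolated protein for displacement of a labelled ligand from metabotropic glutamate receptor 5 (Homo sapiens), with a stated time of 60 min, tested at 1 uM; a higher number here means more inhibition at the concentration tested (going by the name of the read-out), a lower number less inhibition. In this assay compound 2 gives 91%, and this number sits no farther from that of compound 1 `COc1ccc2ncc(S(=O)(=O)c3ccc(Cl)c(Cl)c3)c(N3CCC(C)CC3)c2c1` than the scatter allows, since in this assay compound 1 gives 87%. Going by the values given here, the only measured step, a number 4 percentage points higher from compound 1 to compound 2 (within the scatter), concerns fluoro in place of methoxy on an aromatic carbon and stays within the scatter.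

Compound 3 `CC1CCN(c2c(S(=O)(=O)c3cccc(F)c3)cnc3ccc(F)cc23)CC1` has not yet been measured. It differs from compound 2 in one place: 3-fluorophenyl in place of 3,4-dichlorophenyl on a sulfonyl sulfur. Among the compounds with values here, no measured step touches the group on the sulfonyl sulfur, so the step from compound 2 to compound 3 has no precedent in these data, and the one known step, the exchange on the aromatic carbon, bears only on a different part of the molecule. The expectation for compound 3 therefore rests on the high numbers of both measured compounds and on the absence of any guidance for this exchange; a loss beyond the scatter is thought possible but uncertain. The expected step is a number 21 percentage points lower from compound 2 to compound 3 (beyond the scatter). Compound 3 is estimated to give 70% in this assay, with a range from 35% to 95%.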

Compound 3, a percentage reported as inhibition, at one concentration (the size of the read-out at that concentration, not a potency): 76%
For compound 3 the middle estimate is 6 percentage points below the measured one, within the range that was stated.
By their numbers in this assay, from the lowest: compound 3; then compounds 1 and 2 (each within the scatter of the next).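

Going by these compounds alone, on the sulfonyl sulfur, the aryl group does affect the read-out in this assay: 3-fluorophenyl in place of 3,4-dichlorophenyl gives a number 15 percentage points lower from compound 2 to compound 3 (beyond the scatter) and thus a change that goes beyond the scatter, unlike the only earlier step, which concerned a different part of the molecule. The change is not an all-or-nothing one, since compound 3 still gives 76% at the single concentration tested, so inhibition persists with 3-fluorophenyl on the sulfonyl sulfur. Nothing available here explains this loss.

The exchange removes both chlorines and brings in a fluorine in one step, so these compounds cannot separate the contribution of each, and a phenyl carrying a single chlorine, an unsubstituted phenyl or a pyridine on the sulfonyl sulfur would remain to be compared. On these data alone, it also stays open whether the same loss would appear with methoxy in place of fluoro on the aromatic carbon of the shared core, or with a morpholine in place of the ring amine that all three compounds carry.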